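A few compounds are considered here, and "the series" means these few. Any claim that something is new, unique, unknown or untested is made for them only; others in the source may bear on it.

Compound 3, whose structure is `COc1cc(/C=C/c2nc(N3CCCC3)c3sccc3n2)cc(OC)c1OC`, gives 681000 nM in a functional assay on L02 cells (Homo sapiens) for inhibition, read by Griess assay, with stated times of 1 h and 24 h; on this read-out lower numbers stand for stronger inhibition and higher numbers for weaker inhibition. Of the two numbers that were obtained in this assay, compound 3 has the lower one, and the nearest is compound 1, with structure `CCCc1nn(C)c2c(NCc3ccc(F)cc3)nc(/C=C/c3cccnc3)nc12`, which gives 940000 nM; the gap between the two sits within the usual scatter of the measurement, so the two compounds cannot be told apart on these data. Compound 2, with structure `CN(C)c1nc(/C=C/c2ccccc2)nc2ccsc12`, reaches only a limit of the assay, > 1000000 nM, and no number. That the limit of > 1000000 nM in this assay, at which 1 of the 3 values shown sits, marks the edge beyond which this assay reports no value.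

Compound 4, with structure `COc1cc(/C=C/c2nc(NCc3ccco3)c3sccc3n2)cc(OC)c1OC`, has not yet been measured in this assay. It differs from compound 3 in one place: ((furan-2-yl)methyl)amino in place of pyrrolidin-1-yl on an aromatic carbon. Going by the values given here, no step between two measured compounds is available here to gauge such a change, so the expectation must rest on the range that compounds 1 and 3 occupy. Compound 4 is expected to land close to compound 3, with a step of a 1.1-fold lower number from compound 3 to compound 4 (0.05 log units; within the scatter) that does not clearly leave the scatter in either direction. On that basis compound 4 is estimated at 600000 nM, within a range from 200000 nM to 1500000 nM.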

Compound 4, half-maximal inhibitory concentration: 189000 nM
For compound 4 the middle estimate is 3.2-fold (0.50 log units) above the measured one, outside the stated range (below it).
By their numbers in this assay, from the lowest: compound 4; then compounds 3 and 1 (each within the scatter of the next). At a limit, above all of these: compound 2.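

With pyrrolidin-1-yl replaced by ((furan-2-yl)methyl)amino on an aromatic carbon next to the ring nitrogen, this assay gives a 3.6-fold lower number from compound 3 to compound 4 (0.56 log units; beyond the scatter). This is the first step shown at this position, and because it lies beyond the scatter, it shows that the number in this assay responds to what this carbon carries, which the earlier compounds, differing from one another in more than one place, could not show. The change nonetheless has several parts: it swaps a five-membered non-aromatic ring for a five-membered aromatic ring, adds a hydrogen-bond donor and a hydrogen-bond acceptor, and enlarges the group, and nothing measured here ties the step to any of these features.

The compounds shown leave open whether the furan ring, the amino hydrogen or the group's greater size accounts for the step. A benzylamino group or a methylamino group at this carbon on the same core would begin to separate these, as would morpholin-4-yl set against pyrrolidin-1-yl.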